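The source may hold more compounds than are shown below. What is called first, only, known or untested is meant among the compounds shown, and "the series" means these compounds.

Measured so far in a functional assay on A549 cells (Homo sapiens) for inhibition, read by MTT assay, with a stated time of 48 h, tested at 10 uM; on this read-out lower numbers stand for less inhibition of growth and higher numbers for more inhibition of growth at the one concentration tested:
Compound 1 `O=C(/C=C/c1ccc(OCc2cn(Cc3ccccc3)nn2)cc1)c1ccc(Br)cc1` gives 34%.
Compound 2 `O=C(/C=C/c1ccc(OCc2cn(Cc3cccc(Br)c3)nn2)cc1)c1ccc(Br)cc1` gives 44%.
Compound 3 `O=C(/C=C/c1ccc(OCc2cn(Cc3ccc(F)cc3)nn2)cc1)c1ccc(Br)cc1` gives 43%.

Compound 2 holds the highest of the three numbers, but its neighbours sit close: a number 1 percentage points lower from compound 2 to compound 3 (within the scatter) and, read the other way, a number 10 percentage points higher from compound 1 to compound 2 (within the scatter), both within the scatter, so no order among the three can be claimed. Compound 4 `O=C(/C=C/c1ccc(OCc2cn(Cc3cccc(Br)c3)nn2)cc1)c1ccc([N+](=O)[O-])cc1` is made from compound 2 by one change: nitro in place of bromo on an aromatic carbon.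

Among the compounds with values here, none of the measured steps touches this part of the shared core. The steps of a number 10 percentage points higher from compound 1 to compound 2 (within the scatter) and a number 9 percentage points higher from compound 1 to compound 3 (within the scatter) alter the benzyl ring attached to the aromatic nitrogen, and neither moved the read-out beyond the scatter. Within the data shown here, the exchange of bromo for nitro on the carbonyl-bearing ring has no measured counterpart here, so the expectation must rest on the narrow spread of the three values alone.

On that basis the estimated step of a number 2 percentage points lower from compound 2 to compound 4 (within the scatter) is expected to stay within the scatter, and compound 4 is estimated at 42%, with a range from 25% to 60%.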

Compound 4, percent growth inhibition at one concentration: 28%
Compound 4: middle estimate off by 14 percentage points, on the high side; the measured number falls inside the stated range.
By their numbers in this assay, from the lowest: compounds 4, 1, 3 and 2 (each within the scatter of the next, the first and the last beyond it).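

In this assay, the exchange of bromo for nitro on the aromatic ring of the (4-bromophenyl)carbonyl group gives a number 16 percentage points lower from compound 2 to compound 4 (beyond the scatter). This is the only single change shown that passes the scatter, and it shows that this position can respond to substitution, although the step remains modest. The other two steps from compound 1, a number 10 percentage points higher from compound 1 to compound 2 (within the scatter) and a number 9 percentage points higher from compound 1 to compound 3 (within the scatter), lie within the scatter and show no such response. No measurement shown here explains this step.

The compounds shown leave open whether an amine, a methoxy group or a carboxylic acid at this position would keep or lose growth inhibition. They also leave open whether the same exchange of bromo for nitro would give a similar step in compound 1 or compound 3.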